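Bromo for hydrogen on a pyrrolyl-phenyl oxadiazole scaffold

The source may report more compounds than this note shows. Statements on the series, on what has been measured and on what is new or still open speak of the compounds shown alone.

Compound 1 `c1ccc(-c2nnc(-c3ccc(-n4cccc4)cc3)o2)cc1` and compound 2 `O=[N+]([O-])c1cccc(-c2nnc(-c3ccc(-n4cccc4)cc3)o2)c1` were both tested in an ADME assay on A549 cells (Homo sapiens) for cytotoxicity, read by MTT assay, with a stated time of 72 h; a higher number here means a weaker inhibitor, a lower number a stronger inhibitor. In this assay compound 1 gives 256000 nM, and compound 2 gives 256000 nM; the two stand level, with the step of no change at the digits printed from compound 1 to compound 2 (within the scatter) showing no change within the scatter. Compound 3 `Brc1ccc(-c2nnc(-c3ccc(-n4cccc4)cc3)o2)cc1` differs from compound 1 by bromo in place of hydrogen on an aromatic carbon. Going by the values given here, the only step that bears on this change, from compound 1 to compound 2, was flat, so no step beyond the scatter is expected for compound 3. The expected step is no change at the digits printed from compound 1 to compound 3 (within the scatter). Compound 3 is therefore estimated at 256000 nM, in a range from 128000 nM to 256000 nM.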

Compound 3, half-maximal inhibitory concentration: 264000 nM
Compound 3: the middle estimate sits 1.0-fold (0.01 log units) below what was measured; measured number outside the range, above it.
By their numbers in this assay, from the lowest: compounds 1, 2 and 3 (each within the scatter of the next).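

In this assay, the change from phenyl to 4-bromophenyl gives a 1.0-fold higher number from compound 1 to compound 3 (0.01 log units; within the scatter), so a bromo on an aromatic carbon para to a large group leaves the number where it was. With the nitro step no change at the digits printed from compound 1 to compound 2 (within the scatter), this makes two replacements of hydrogen on this ring of the core of compound 1, and neither moves the number beyond the scatter. No measurement at hand accounts for this flat result.

Going by these compounds, whether an amine or a carboxylic acid at this position would shift the number remains open. So does the effect of any replacement on the pyrrole ring.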